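The source may hold more compounds than are shown below. What is called first, only, known or untested is meant among the compounds shown, and "the series" means these compounds.

In a functional assay (muscle tissue) with Cavia porcellus as the target (a lower number here means that less compound is needed, a higher number that more compound is needed for the effect), compound 1 (`CCc1ccccc1C1C(C(=O)OC)=C(C)N=C(C)/C1=C(\O)OC`) gives 6.46 nM. Compound 2 (`C=Cc1ccccc1C1C(C(=O)OC)=C(C)N=C(C)/C1=C(\O)OC`) gives 4.47 nM, so the two stand together within the usual scatter. Within the data shown here, the only measured step, vinyl in place of ethyl on an aromatic carbon, is a 1.4-fold lower number from compound 1 to compound 2 (0.16 log units; within the scatter). Compound 3 (`COC(=O)C1=C(C)N=C(C)/C(=C(\O)OC)C1c1ccc(C#N)cc1`) now carries 4-cyanophenyl in place of 2-vinylphenyl on a saturated ring carbon. This is a larger change than the measured one, since both the group and its place on the phenyl ring differ. Among the measured compounds shown here, the small step to compound 2, a 1.4-fold lower number from compound 1 to compound 2 (0.16 log units; within the scatter), therefore offers little guidance, and no measured compound carries a nitrile or a 4-substituted phenyl. A clear move towards a higher number is nevertheless expected, with wide uncertainty, and the estimated step is a 67-fold higher number from compound 2 to compound 3 (1.83 log units; beyond the scatter). For compound 3 the estimated value is 300 nM, within a range of 40 nM to 2000 nM.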

Compound 3, half-maximal effective concentration: 3470 nM
Estimate against measurement, compound 3: 12-fold (1.06 log units) below; measured number above the stated range.
By their numbers in this assay, from the lowest: compounds 2 and 1 (each within the scatter of the next); then compound 3.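

The aryl group on this saturated ring carbon matters far more to this assay than the earlier swap of ethyl for vinyl suggested: 4-cyanophenyl in place of 2-vinylphenyl gives a large rise (a 780-fold higher number from compound 2 to compound 3 (2.89 log units; beyond the scatter)), and 4-cyanophenyl in place of 2-ethylphenyl gives a rise of similar scale (a 540-fold higher number from compound 1 to compound 3 (2.73 log units; beyond the scatter)). The position therefore does not accept every phenyl group equally, and the loss appears from either starting compound, so it does not depend on whether the replaced group carried vinyl or ethyl. No measurement shown here explains this jump.

Since the group and its place on the phenyl ring change together, these compounds cannot show which of the two drives the rise. A 2-cyanophenyl or a 4-ethylphenyl at this position would separate the two, and a plain phenyl would offer a further reference point.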